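From tert-butyl to ethyl on compound 3

This account rests on a few compounds, and the source may have more. Where it says the series, first, only, none or still open, it means among the compounds named here.

Compound 1 `CC(C)(C)NCc1cc(Cl)cc(Nc2nc3ccccc3n2Cc2ccc(C(F)(F)F)cc2)c1O`: < 5000 nM (a limit)
Compound 2 `CCNCc1cc(Cl)cc(Nc2nc3ccccc3n2Cc2ccc(C(F)(F)F)cc2)c1O`: 12000 nM
Compound 3 `Cc1cc(CNC(C)(C)C)c(O)c(Nc2nc3cc(F)c(F)cc3n2Cc2ccc(C(F)(F)F)cc2)c1`: < 5000 nM (a limit)

All three compounds were measured in a physicochemical assay for solubility, read by HPLC, measured as kinetic solubility, with a stated time of 24 h, at pH 6.5; on this read-out lower numbers stand for lower solubility and higher numbers for higher solubility. Compound 3 gives < 5000 nM, which is a limit and not a number. Compound 3 thus stands at the limit of < 5000 nM in this assay, at which 2 of the 3 values shown sit.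

Compound 4 `CCNCc1cc(C)cc(Nc2nc3cc(F)c(F)cc3n2Cc2ccc(C(F)(F)F)cc2)c1O` differs from compound 3 in one place: ethyl in place of tert-butyl on an amine nitrogen. In words, this is ethyl in place of tert-butyl on an amine nitrogen. The same exchange has been measured once, with an at least 2.4-fold higher number from compound 1 to compound 2 (0.38 log units; beyond the scatter). That step starts from a limit, so its full size is not known. Compound 3 also differs from compound 1 elsewhere on the core, so the step may not carry over unchanged.

On the evidence of an at least 2.4-fold higher number from compound 1 to compound 2 (0.38 log units; beyond the scatter), a modest rise beyond the scatter is expected for compound 4 in this assay. The expected change is an at least 1.6-fold higher number from compound 3 to compound 4 (0.20 log units; that floor lies within the scatter). Compound 4 is estimated at 8000 nM, with an expected range from 3500 nM to 18000 nM.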

Compound 4, solubility: 16000 nM
Estimate against measurement, compound 4: 2.0-fold (0.30 log units) below; low and high end bracket the measured number.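

Ethyl in place of tert-butyl on the amine nitrogen, read in this assay, now gives an at least 3.2-fold higher number from compound 3 to compound 4 (0.50 log units; beyond the scatter). The same exchange gave an at least 2.4-fold higher number from compound 1 to compound 2 (0.38 log units; beyond the scatter), so the rise beyond the scatter holds on both the core of compound 1 and the core of compound 3, and no longer rests on a single pair. Both steps start from a limit, so only their floors are known and their full sizes cannot be set against each other: the limit of < 5000 nM in this assay, at which 2 of the 4 values shown sit.

The compounds shown leave open whether methyl or the unsubstituted amine would continue this trend, and whether a longer chain such as propyl or a ring such as cyclopropyl on the same nitrogen would match ethyl. They also leave open what actual numbers compound 1 and compound 3 would give.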